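The compounds below may be only part of what the source reports. "The series", "measured", "known", "first", "only" and "open" are said of these compounds alone.

Compound 1 `CC(NC(=O)CN)C(=O)N(C)c1ccc(Cl)cc1C(=O)c1ccccc1Cl`: 0.47 mg/kg
Compound 2 `CCCC(=O)NCC(=O)N(C)c1ccc(Cl)cc1C(=O)c1ccccc1Cl`: 0.98 mg/kg

In a functional assay on the whole organism for antagonist activity, with Mus musculus as the target (on this read-out higher numbers stand for an effect only at larger amounts of compound and lower numbers for an effect already at smaller amounts), compound 2 gives 0.98 mg/kg, the highest of the two numbers recorded so far. Compound 1 gives 0.47 mg/kg. Among the measured compounds shown here, the only measured step, a 2.1-fold higher number from compound 1 to compound 2 (0.32 log units; beyond the scatter), is modest and concerns the group attached to a carbonyl carbon of the shared core. Compound 3 `CN1CCN(CC(=O)NCC(=O)N(C)c2ccc(Cl)cc2C(=O)c2ccccc2Cl)CC1` has not yet been measured. It differs from compound 2 by 4-methylpiperazin-1-yl in place of ethyl on a saturated chain carbon bound to a carbonyl carbon. For the measured compounds named here, no measured step covers this exchange; the one step available shows only that a change of the group on the carbonyl carbon moves the number modestly. A step of at most modest size is therefore expected, with no clear direction, and compound 3 is estimated to give 1 mg/kg in this assay, within a range of 0.4 mg/kg to 2.5 mg/kg. The step so expected is a 1.0-fold higher number from compound 2 to compound 3 (0.01 log units; within the scatter).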

Compound 3, dose for half-maximal effect: 59 mg/kg
Beside the measured number, compound 3's estimate is 59-fold (1.77 log units) below it; measured number outside the range, above it.
By their numbers in this assay, from the lowest: compound 1; then compound 2; then compound 3.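

In this assay, the exchange of ethyl for 4-methylpiperazin-1-yl on a saturated chain carbon bound to a carbonyl carbon gives a 60-fold higher number from compound 2 to compound 3 (1.78 log units; beyond the scatter) and so marks this position as far more sensitive than a 2.1-fold higher number from compound 1 to compound 2 (0.32 log units; beyond the scatter) had indicated. The change adds a six-membered non-aromatic ring with 2 hetero atoms, and compound 3 now needs much larger amounts than compound 2 for the same effect. No measured information available here explains the size of this step.

The compounds shown leave open whether the ring as such or its nitrogens account for the step. A piperidine, a morpholine or an open-chain dimethylamino group at this place would separate these possibilities, and a longer alkyl chain would show how much larger the group can grow without such a step.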